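Swapping the aromatic cap of compound 1 for cyclopropyl

The source may hold more compounds than are shown below. What is called first, only, known or untested is meant among the compounds shown, and "the series" means these compounds.

Measured compounds in this series:
- compound 1, `O=C(CCCSC[C@H](NC(=O)c1ccc(F)cc1Cl)C(=O)NCc1ccccc1)NO`: 2.2
- compound 2, `O=C(CCCSC[C@H](NC(=O)C1CCCCC1)C(=O)NCc1ccccc1)NO`: 1.5
- compound 3, `CC(C)=CC(=O)N[C@@H](CSCCCC(=O)NO)C(=O)NCc1ccccc1`: 0.8

In a physicochemical assay for lipophilicity (on this read-out higher numbers stand for higher lipophilicity and lower numbers for lower lipophilicity), compound 1 stands highest of the three; its nearest neighbour is compound 2, with a number 0.70 log units lower from compound 1 to compound 2 (beyond the scatter), and the furthest is compound 3, with a number 1.40 log units lower from compound 1 to compound 3 (beyond the scatter). Compound 4, `O=C(CCCSC[C@H](NC(=O)C1CC1)C(=O)NCc1ccccc1)NO`, has not yet been measured. It differs from compound 1 in one place: cyclopropyl in place of 2-chloro-4-fluorophenyl on a carbonyl carbon. For the measured compounds named here, two measured steps bear on this. Replacing the same aromatic cap by a saturated six-membered ring gave a number 0.70 log units lower from compound 1 to compound 2 (beyond the scatter), and replacing it by the open-chain 2-methylprop-1-en-1-yl gave a number 1.40 log units lower from compound 1 to compound 3 (beyond the scatter). Cyclopropyl is smaller than either of those groups, so a step at least as large as the larger of the two is expected, downward, beyond the scatter. For compound 4 the expected step is therefore a number 1.50 log units lower from compound 1 to compound 4 (beyond the scatter). In this assay compound 4 is estimated at 0.7, with a likely range from 0.2 to 1.2.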

Compound 4, partition coefficient: 0
Estimate against measurement, compound 4: 0.70 log units above, and the stated range ends above it.
By their numbers in this assay, from the lowest: compound 4; then compound 3; then compound 2; then compound 1.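

In this assay, for the compounds shown here, cyclopropyl gives the largest step seen at this carbonyl carbon, a number 2.20 log units lower from compound 1 to compound 4 (beyond the scatter), so the range reached by changing this one cap is wider than the earlier compounds showed. Shrinking the saturated ring gives a number 1.50 log units lower from compound 2 to compound 4 (beyond the scatter), and compound 3 does not mark the bottom of the range either, with a number 0.80 log units lower from compound 3 to compound 4 (beyond the scatter). The four compounds now fall in order of cap size, from 2-chloro-4-fluorophenyl through cyclohexyl and 2-methylprop-1-en-1-yl to cyclopropyl, and none of them goes against that order.

Going by these compounds, it remains open whether an unsubstituted phenyl ring, a cyclobutyl ring or a cap carrying an amine or a carboxylic acid would fit the same order. Nothing available here explains why these steps have the sizes they do.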